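Removal of the remaining methyl from compound 3

The source may report more compounds than this note shows. Statements on the series, on what has been measured and on what is new or still open speak of the compounds shown alone.

Measured compounds:
compound 1 `Cc1cnc2nc(-c3ccc4ccccc4c3)cc(O)c2c1`: 105 nM
compound 2 `Cc1cc(C)c2c(O)cc(-c3ccc4ccccc4c3)nc2n1`: 2950 nM
compound 3 `Cc1ccnc2nc(-c3ccc4ccccc4c3)cc(O)c12`: 204 nM

In a functional assay on MDA-MB-435 cells (Homo sapiens) for antiproliferative activity (on this read-out lower numbers stand for stronger inhibition of growth and higher numbers for weaker inhibition of growth), compound 3 sits second highest of the three numbers; compound 1 is within the scatter of it, while compound 2 lies well beyond. Compound 4 `Oc1cc(-c2ccc3ccccc3c2)nc2ncccc12` differs from compound 3 by hydrogen in place of methyl on an aromatic carbon. Within the data shown here, the only measured step of the same kind, a 14-fold lower number from compound 2 to compound 3 (1.16 log units; beyond the scatter), removed a methyl at a different place on the same ring, so it bears only loosely on this change. Because a 14-fold lower number from compound 2 to compound 3 (1.16 log units; beyond the scatter) was large and downward, a smaller move in the same direction is expected here, a 2.0-fold lower number from compound 3 to compound 4 (0.31 log units; beyond the scatter), though the gap between compound 1 and compound 3 shows that methyl placement can also make little difference. Compound 4 is estimated at 100 nM, between 30 nM and 400 nM.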

Compound 4, concentration for 50% growth inhibition: 1780 nM
The estimate for compound 4 lay 18-fold (1.25 log units) below the measured number; the measured number lies above the stated range.
By their numbers in this assay, from the lowest: compounds 1 and 3 (each within the scatter of the next); then compounds 4 and 2 (each within the scatter of the next).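

In this assay, taking the last methyl off the ring gives an 8.7-fold higher number from compound 3 to compound 4 (0.94 log units; beyond the scatter), and the other placement of a lone methyl gives a 17-fold higher number from compound 1 to compound 4 (1.23 log units; beyond the scatter), so on these compounds either lone methyl goes with a lower number than hydrogen. Hydrogen in place of methyl on an aromatic carbon of this ring therefore has no single direction, and the outcome depends on the core that carries the change: the same change on two cores in this assay, a 14-fold lower number (1.16 log units; beyond the scatter) from compound 2 to compound 3 and a 17-fold higher number (1.23 log units; beyond the scatter) from compound 1 to compound 4, 250-fold (2.39 log units) apart, beyond the scatter of two such steps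

On these data alone, whether the lower number needs a methyl as such remains open. An ethyl, a methoxy or an amine at the place held by the methyl of compound 3 would test this.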